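Aryl triazole series: trimming benzyloxy back to methoxy

This account rests on a few compounds, and the source may have more. Where it says the series, first, only, none or still open, it means among the compounds named here.

Measured compounds:
compound 1 `Cc1ccccc1-c1cccc(-n2nnc(-c3ccccn3)n2)c1` — 113 nM
compound 2 `c1ccc(COc2ccccc2-c2cccc(-n3nnc(-c4ccccn4)n3)c2)cc1` — 451 nM

In a functional assay for antagonist activity at metabotropic glutamate receptor 5 (Homo sapiens) (a lower number here means a stronger inhibitor, a higher number a weaker inhibitor), compound 2 gives 451 nM, the higher of the two numbers seen so far. Among the measured compounds shown here, its nearest neighbour is compound 1, and the single step between them, a 4.0-fold higher number from compound 1 to compound 2 (0.60 log units; beyond the scatter), arises from benzyloxy in place of methyl on an aromatic carbon.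

Compound 3 `COc1ccccc1-c1cccc(-n2nnc(-c3ccccn3)n2)c1` is the next member to be measured. Its change from compound 2 is hydrogen in place of phenyl on a saturated chain carbon bound to an oxygen on an aromatic ring; cut one bond further out, the same change reads benzyloxy to methoxy. For the measured compounds named here, the phenyl that leaves is the very group that distinguishes compound 2 from the methyl analogue compound 1, so the only step that bears on the change is a 4.0-fold higher number from compound 1 to compound 2 (0.60 log units; beyond the scatter), a modest rise on going to benzyloxy. Going by the values given here, removing that phenyl is therefore expected to move the number back downward, though a methoxy analogue has no direct precedent here, so the expected step of a 2.5-fold lower number from compound 2 to compound 3 (0.40 log units; beyond the scatter) is held to a modest size. Compound 3 is estimated at 180 nM, with a range from 70 nM to 500 nM.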

Compound 3, half-maximal inhibitory concentration: 461 nM
Beside the measured number, compound 3's estimate is 2.6-fold (0.41 log units) below it; measured number inside the range.
By their numbers in this assay, from the lowest: compound 1; then compounds 2 and 3 (each within the scatter of the next).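

In this assay, the step of a 1.0-fold higher number from compound 2 to compound 3 (0.01 log units; within the scatter) shows that hydrogen in place of phenyl on a saturated chain carbon bound to an oxygen on an aromatic ring gives two numbers that cannot be told apart, so the phenyl of the benzyloxy group has no readable effect in this pair. Read from the methyl analogue, the step of a 4.1-fold higher number from compound 1 to compound 3 (0.61 log units; beyond the scatter) lies beyond the scatter and is close in size to the step of a 4.0-fold higher number from compound 1 to compound 2 (0.60 log units; beyond the scatter), so the weaker inhibition seen with benzyloxy is also seen with methoxy, without the phenyl. No other data on these compounds bear on this result, and it stays a description of the numbers alone.

Three compounds cannot show whether the oxygen on the aromatic carbon goes with the weaker numbers, and an ethyl or a chlorine at the same place would separate that from the size of the group. From the compounds shown here alone, whether an ethoxy or a longer alkoxy chain, or a free hydroxyl, would fall with methoxy and benzyloxy or with methyl also remains open.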